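Phenyl for Cyclohexyl: Expecting Another Limit

This account rests on a few compounds, and the source may have more. Where it says the series, first, only, none or still open, it means among the compounds named here.

Compound 1 `COC(=O)c1nc(C)n(-c2ccc(F)cc2)n1` gives 8700 nM in a functional assay on Jurkat cells (Homo sapiens) for inhibition, read by MTT assay, with a stated time of 72 h; a lower number here means a stronger inhibitor of growth, a higher number a weaker inhibitor of growth.
Compound 2 `COC(=O)c1nc(C(C)C)n(-c2ccc(F)cc2)n1` reaches only the limit > 100000 nM in this assay.
Compound 3 `COC(=O)c1nc(C2CCCCC2)n(-c2ccc(F)cc2)n1` likewise reaches only the limit > 100000 nM in this assay.

Compound 3 thus stands at the limit of > 100000 nM in this assay, at which 2 of the 3 values shown sit, and the same is true of compound 2, so no number for either is known. Compound 4 `COC(=O)c1nc(-c2ccccc2)n(-c2ccc(F)cc2)n1` differs from compound 3 in one place: phenyl in place of cyclohexyl on an aromatic carbon. The measured steps that bear on this change are the two that move away from the methyl of compound 1: an at least 11-fold higher number from compound 1 to compound 2 (1.06 log units; beyond the scatter) and an at least 11-fold higher number from compound 1 to compound 3 (1.06 log units; beyond the scatter). On these data alone, both go in the same direction, toward a higher number in this assay, but the step between them, a step that the two limits leave unreadable from compound 2 to compound 3, cannot be read, so whether a six-membered ring behaves differently from a branched chain on this carbon of the shared core is unknown. Phenyl is a six-membered ring, as cyclohexyl is, only aromatic, and nothing measured here separates aromatic from saturated at this place. Compound 4 is therefore expected to sit near the same limit, with a number no higher from compound 3 to compound 4 (the limit leaves the size open) as the expected step to it. The estimate for compound 4 is 100000 nM, from 20000 nM to 300000 nM.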

Compound 4, concentration for 50% growth inhibition: 10000 nM
Compound 4: middle estimate off by 10-fold (1.00 log units), on the high side; measured number outside the range, below it.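

Among these compounds, on the aromatic carbon between two ring nitrogen atoms, the two six-membered rings do not behave alike in this assay: phenyl in place of cyclohexyl gives an at least 10-fold lower number from compound 3 to compound 4 (1.00 log units; beyond the scatter), a separation of aromatic from saturated that the earlier compounds could not show. Phenyl in place of isopropyl gives an at least 10-fold lower number from compound 2 to compound 4 (1.00 log units; beyond the scatter), whereas phenyl in place of methyl gives a 1.1-fold higher number from compound 1 to compound 4 (0.06 log units; within the scatter), so among the four groups shown, phenyl and methyl cannot be told apart, while isopropyl and cyclohexyl both end at a limit. The two lower steps start from limits and not from numbers, so their true sizes stay open: the limit of > 100000 nM in this assay, at which 2 of the 4 values shown sit.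

On these data alone, what happens when the phenyl ring carries a further group, such as an amine or a methoxy group, remains open, as does the effect of a straight chain such as ethyl on this carbon. Also open, as far as these compounds go, is whether the pattern holds when a carboxylic acid or an amide takes the place of the methoxycarbonyl group on the shared core.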